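This account rests on a few compounds, and the source may have more. Where it says the series, first, only, none or still open, it means among the compounds named here.

Compound 1, `O=S(=O)(/C=C/c1ccccc1)Nc1ccccc1`: > 10000 nM in an assay on U2OS cells for activation of nuclear factor erythroid 2-related factor 2 (Homo sapiens), read by chemiluminescence, with a stated time of 6 h (on this read-out lower numbers stand for an effect already at smaller amounts and higher numbers for an effect only at larger amounts of compound), a limit of the assay.
Compound 2, `COc1ccc(OS(=O)(=O)/C=C/c2ccccc2)cc1`: 1480 nM in this assay.
Compound 3, `COc1cccc(OS(=O)(=O)/C=C/c2ccccc2Cl)c1`: 165 nM in this assay.

Compound 2 holds the higher of the two numbers; compound 3 gives a lower value, a gap beyond the scatter. Compound 4, `COc1ccc(OS(=O)(=O)/C=C/c2ccc(Cl)cc2)cc1`, awaits measurement in this assay. The change from compound 2 is chloro in place of hydrogen on an aromatic carbon. Among the compounds with values here, no measured pair of the series isolates this change. Compound 3, carrying a chloro on the same ring, shows the lower number, so a moderate step toward lower numbers is expected, a 2.1-fold lower number from compound 2 to compound 4 (0.33 log units; beyond the scatter). Compound 4 is accordingly expected to give 700 nM in this assay, with a range from 250 nM to 2500 nM.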

Compound 4, half-maximal effective concentration: 1160 nM
The estimate for compound 4 lay 1.7-fold (0.22 log units) below the measured number; measured number inside the range.
By their numbers in this assay, from the lowest: compound 3; then compounds 4 and 2 (each within the scatter of the next). At a limit, above all of these: compound 1.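

Chloro in place of hydrogen on an aromatic carbon, para to a large group, can now be read as a single change: in this assay it gives a 1.3-fold lower number from compound 2 to compound 4 (0.11 log units; within the scatter). At this position, the chloro therefore moves the number no further than the scatter, and the lower value of compound 3 cannot be assigned to a chloro alone, since compound 3 differs from compound 4 in more than one place. Nothing at hand bears on a cause for this step. From the compounds shown here alone, whether an amine, a nitrile or a carboxylic acid at this position would shift the number remains open. So does the effect of chloro alone at other places on that ring.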